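A few compounds are considered here, and "the series" means these few. Any claim that something is new, unique, unknown or untested is made for them only; others in the source may bear on it.

Measured compounds:
compound 1, `CCN(CC)C(=O)c1ccncc1OC[C@@H]1CCCN1C`, in an assay on membranes from brain for displacement of a labelled ligand from Neuronal acetylcholine receptor; alpha4/beta2 (Rattus norvegicus) (on this read-out higher numbers stand for weaker inhibition and lower numbers for stronger inhibition), compound 1 gives 2830 nM
compound 2, `CN1CCC[C@H]1COc1cncc(C(F)(F)F)c1`, in this assay compound 2 gives 1.83 nM

Compound 2 stands at the lowest number of the two, and the number for compound 1 lies far above it, well beyond the usual scatter. Compound 3, `CN1CCC[C@H]1COc1cncc(F)c1`, is not yet measured. It differs from compound 2 in one place: fluoro in place of trifluoromethyl on an aromatic carbon. Going by the values given here, no measured pair shows a change of this kind here, so the size of the step cannot be read from the data. The step of a 1.1-fold higher number from compound 2 to compound 3 (0.04 log units; within the scatter) is expected to be small, in no clear direction, and within the scatter. For compound 3 a value near 2 nM is expected, between 0.5 nM and 8 nM.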

Compound 3, inhibition constant: 0.69 nM
Compound 3: the middle estimate sits 2.9-fold (0.46 log units) above what was measured; the measured number falls inside the stated range.
By their numbers in this assay, from the lowest: compound 3; then compound 2; then compound 1.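

Replacing trifluoromethyl with fluoro at this position gives a 2.7-fold lower number from compound 2 to compound 3 (0.42 log units; beyond the scatter), a modest but real shift. The larger group is therefore not needed for a low number in this assay, and this position accepts at least two different fluorine-bearing groups while the number stays low.

As far as these compounds go, whether a chlorine atom, a nitrile or an amine in the same place would lower or raise the number remains open. No measurement shown gives a reason for this step.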